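Chlorine position shift on the aldimine aryl ring

The compounds below may be only part of what the source reports. "The series", "measured", "known", "first", "only" and "open" are said of these compounds alone.

Working notes on the series in a functional assay on HCT-116 cells (Homo sapiens) for cytotoxicity, read by MTT assay, with a stated time of 72 h; a higher number here means a weaker inhibitor, a lower number a stronger inhibitor. Compound 1 `CCOc1cccc(/C=N/c2c(C)n(C)n(-c3ccccc3)c2=O)c1` gives 933000000 nM; compound 2 `Cc1c(/N=C/c2ccccc2Cl)c(=O)n(-c2ccccc2)n1C` gives 851000000 nM; compound 3 `Cc1c(/N=C/c2ccc(Cl)cc2)c(=O)n(-c2ccccc2)n1C` gives 589000000 nM. Compound 3 carries the lowest of the three numbers, but its gaps to compound 2 and to compound 1 both lie within the scatter, so no ranking among the three can be read. Going by the values given here, the one measured step that bears on the chlorine position, a 1.4-fold lower number from compound 2 to compound 3 (0.16 log units; within the scatter), was itself within the scatter. Compound 4 `Cc1c(/N=C/c2cccc(Cl)c2)c(=O)n(-c2ccccc2)n1C` differs from compound 3 by 3-chlorophenyl in place of 4-chlorophenyl on a carbon with a double bond to nitrogen. Among the compounds with values here, with only that single small step as precedent, compound 4 is expected to show a step of a 1.1-fold higher number from compound 3 to compound 4 (0.04 log units; within the scatter), not beyond the scatter. Compound 4 is therefore estimated at 650000000 nM, ranging from 300000000 nM to 1400000000 nM.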

Compound 4, half-maximal inhibitory concentration: 912000000 nM
The estimate for compound 4 lay 1.4-fold (0.15 log units) below the measured number, within the range that was stated.
By their numbers in this assay, from the lowest: compounds 3, 2, 4 and 1 (each within the scatter of the next).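

In this assay, the chlorine position makes no readable difference: a 1.5-fold higher number from compound 3 to compound 4 (0.19 log units; within the scatter) and a 1.1-fold higher number from compound 2 to compound 4 (0.03 log units; within the scatter) both stay within the scatter, so 2-chlorophenyl, 3-chlorophenyl and 4-chlorophenyl cannot be told apart. The step of a 1.0-fold lower number from compound 1 to compound 4 (0.01 log units; within the scatter) adds a different change, chloro in place of ethoxy on an aromatic carbon, and this too stays within the scatter. Nothing measured offers an explanation for these results. Still open, as far as these compounds go, is whether an amine or a carboxylic acid in place of the chloro group would give a step beyond the scatter.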